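Working notes: an isomeric exchange on the ether oxygen

This account rests on a few compounds, and the source may have more. Where it says the series, first, only, none or still open, it means among the compounds named here.

Measured so far:
- compound 1 `COc1cccc(/C=C/C(=O)c2cccc(-n3cc(COc4ccc5ccc(=O)oc5c4)nn3)c2)c1OC` gives 15700 nM
- compound 2 `COc1cccc(/C=C/C(=O)c2ccc(-n3cc(COc4ccc5ccc(=O)oc5c4)nn3)cc2)c1OC` gives 8180 nM

Both values come from a functional assay on HepG2 cells (Homo sapiens) for cytotoxicity, read by MTT assay, with a stated time of 48 h (on this read-out lower numbers stand for stronger inhibition and higher numbers for weaker inhibition), and lie within the scatter of each other, so these numbers do not set compound 1 apart from compound 2.

Compound 3 `COc1cccc(/C=C/C(=O)c2cccc(-n3cc(COc4cc(=O)oc5ccccc45)nn3)c2)c1OC` is still unmeasured. Compared with compound 1 it shows a group of 11 heavy atoms (9 carbon, 2 oxygen; one six-membered aromatic ring of carbon only, one six-membered aromatic ring with 1 hetero atom) in place of a group of 11 heavy atoms (9 carbon, 2 oxygen; one six-membered aromatic ring of carbon only, one six-membered aromatic ring with 1 hetero atom), on an oxygen on a saturated carbon and the two hold the same atoms, joined differently. Within the data shown here, no measured pair shows a change of this kind, so the data give no direction for it. In this assay no step beyond the scatter is expected, and the expectation rests on compound 1 with its 15700 nM as the anchor. The estimated step of a 1.2-fold lower number from compound 1 to compound 3 (0.08 log units; within the scatter) is expected to be small, with wide uncertainty on either side. For compound 3 the expected value is 13000 nM with an estimated range from 4500 nM to 38000 nM in this measurement.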

Compound 3, half-maximal inhibitory concentration: 4260 nM
Compound 3: the middle estimate sits 3.1-fold (0.48 log units) above what was measured; measured number outside the range, below it.
By their numbers in this assay, from the lowest: compounds 3, 2 and 1 (each within the scatter of the next, the first and the last beyond it).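

In this assay, among these compounds, exchanging one of these two isomeric groups for the other on an oxygen on a saturated carbon gives a 3.7-fold lower number from compound 1 to compound 3 (0.57 log units; beyond the scatter), the first step that lies beyond the scatter and the first reading of any change at this place. Both groups hold 11 heavy atoms, with the same counts of carbon and oxygen, the same aromatic ring types, one double bond outside aromatic rings, and 2 hydrogen-bond acceptors, so the step separates two groups that differ only in how their atoms are joined, and the result shows that this place is sensitive to that difference even with the composition unchanged. Nothing available bears on the reason for the step.

From the compounds shown here alone, whether the step carries over to the core of compound 2 remains open, since the group entering in compound 3 appears here only on the core of compound 1. Also open, going by these compounds, is how this place responds to a change of composition rather than connectivity, such as an amine or a carboxylic acid on the group, or a longer chain in place of the saturated carbon link.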